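Cyclohexyl for butyl on the sulfur of compound 2

The compounds below may be only part of what the source reports. "The series", "measured", "known", "first", "only" and "open" are said of these compounds alone.

Measured compounds:
compound 1 `CC(C(=O)NCc1ccc(C(C)(C)C)cc1OCc1ccccc1)c1ccc(NS(C)(=O)=O)c(F)c1` gives 2.9 nM
compound 2 `CCCCSc1cc(C(C)(C)C)ccc1CNC(=O)C(C)c1ccc(NS(C)(=O)=O)c(F)c1` gives 6.7 nM

In an assay on cells for antagonist activity at transient receptor potential cation channel subfamily V member 1 (Homo sapiens), read by FLIPR and calcium flux, with a stated time of 6 min (on this read-out lower numbers stand for stronger inhibition and higher numbers for weaker inhibition), compound 2 stands as the higher of the two numbers, with compound 1 nearest at a 2.3-fold higher number from compound 1 to compound 2 (0.36 log units; beyond the scatter). Compound 3 `CC(C(=O)NCc1ccc(C(C)(C)C)cc1SC1CCCCC1)c1ccc(NS(C)(=O)=O)c(F)c1` differs from compound 2 by cyclohexyl in place of butyl on a sulfur. No measured step changes the group on the sulfur itself; the only step shown, a 2.3-fold higher number from compound 1 to compound 2 (0.36 log units; beyond the scatter), replaces a ring-bearing group with butylsulfanyl and is modest. A step of similar or smaller size is therefore expected, with no clear direction. For compound 3 the estimate is 5 nM, in the range 2 nM to 15 nM, meaning a 1.3-fold lower number from compound 2 to compound 3 (0.13 log units; within the scatter).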

Compound 3, inhibition constant: 7.4 nM
For compound 3 the middle estimate is 1.5-fold (0.17 log units) below the measured one, within the range that was stated.
By their numbers in this assay, from the lowest: compound 1; then compounds 2 and 3 (each within the scatter of the next).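

In this assay, a ring of carbon on the sulfur and an open butyl chain read alike (a 1.1-fold higher number from compound 2 to compound 3 (0.04 log units; within the scatter)), so closing the chain into cyclohexyl and adding carbon make no clear difference at this place. Compound 1, with benzyloxy, still holds the lower number against cyclohexylsulfanyl (a 2.6-fold higher number from compound 1 to compound 3 (0.41 log units; beyond the scatter)), as it does against butylsulfanyl. Nothing available explains this result. Still open, going by these compounds, is how a sulfur-bound chain carrying an amine or a carboxylic acid would read. Open too, on these data alone, is how benzylsulfanyl would compare with the benzyloxy of compound 1.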